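The source may report more compounds than this note shows. Statements on the series, on what has been measured and on what is new or still open speak of the compounds shown alone.

In a physicochemical assay for lipophilicity, measured as octanol-water partition (a higher number here means a more lipophilic compound, a lower number a more polar compound), compound 1 (`CC(C)[C@@H]1CC[C@@H](C)C[C@H]1OC(=O)c1cccc([N+](=O)[O-])c1`) gives 4.78. This is the lower of the two numbers available: compound 2 (`CC(C)[C@@H]1CC[C@@H](C)C[C@H]1OC(=O)c1ccc(Cl)cc1`) gives 5.34, and the gap between them lies beyond the scatter. Compound 3 (`CC(C)[C@@H]1CC[C@@H](C)C[C@H]1OC(=O)c1cccc(Br)c1`) is still unmeasured. It departs from compound 1 in one place, with bromo in place of nitro on an aromatic carbon, meta to a large group: bromo in place of nitro on an aromatic carbon. The rest of the structure is unchanged.

Among the measured compounds shown here, no measured pair isolates a single change, so the expectation rests on this structural change and on two values only. For the measured compounds named here, the one halogen-bearing compound measured so far, compound 2 at 5.34, stands above compound 1, and a rise in this assay beyond the scatter is expected for the bromo compound as well. The expected change is a number 0.72 log units higher from compound 1 to compound 3 (beyond the scatter). Going by the values given here, with no measured step to calibrate it, the range is kept wide. The estimated value for compound 3 is 5.5, with an expected range of 5.15 to 5.85.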

Compound 3, partition coefficient: 5.61
Compound 3: middle estimate off by 0.11 log units, on the low side; measured number inside the range.
By their numbers in this assay, from the lowest: compound 1; then compounds 2 and 3 (each within the scatter of the next).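

In this assay, among the compounds shown here, the change from nitro to bromo on an aromatic carbon, meta to a large group, gives a number 0.83 log units higher from compound 1 to compound 3 (beyond the scatter), and this is the first step that isolates a single change. It shows that the number at this position depends on the group placed there and is not set by the shared core alone, since the rest of the structure stays the same across the step. The change removes 3 heavy atoms and 2 hydrogen-bond acceptors and brings in 1 heavy atom and 0 hydrogen-bond acceptors, but nothing available separates these differences or shows which of them accounts for the step.

For the compounds shown here, compound 2 does not pair with compound 1 or compound 3 through a single change, so the series still offers only one readable step, from one pair of groups at one position. On these data alone, how an amine, a carboxylic acid or a methoxy group at this same place would read against nitro and bromo remains open, as does whether the step would keep its size with the same swap elsewhere on the aromatic ring.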